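A Pyrrole in Place of a Thiophene on the Shared Core

The compounds below may be only part of what the source reports. "The series", "measured", "known", "first", "only" and "open" are said of these compounds alone.

Of the compounds shown here, two on the shared core have been measured in a functional assay on Jurkat cells (Homo sapiens) for inhibition, read by MTT assay, with a stated time of 72 h; on this read-out higher numbers stand for weaker inhibition of growth and lower numbers for stronger inhibition of growth. Compound 1 `COC(=O)c1nc(C2CCCC2)n(-c2ccc(C(F)(F)F)cc2)n1` carries a cyclopentyl group, and in this assay compound 1 gives > 100000 nM, which is a limit of the assay and not a number. Compound 2 `COC(=O)c1nc(-c2ccsc2)n(-c2ccc(C(F)(F)F)cc2)n1` carries a thiophen-3-yl group in its place, and in this assay compound 2 gives > 100000 nM, again a limit of the assay. The step from compound 1 to compound 2 is accordingly a step that the two limits leave unreadable from compound 1 to compound 2. Compound 2 thus stands at the limit, as the limit of > 100000 nM in this assay, at which 2 of the 2 values shown sit, shows. Compound 3 `COC(=O)c1nc(-c2ccc[nH]2)n(-c2ccc(C(F)(F)F)cc2)n1` differs from compound 2 by 1H-pyrrol-2-yl in place of thiophen-3-yl on an aromatic carbon. For the measured compounds named here, no measured step reads out a size for this kind of change, so no move beyond the scatter is expected in this assay, and a further limit is the likelier outcome. Compound 3 is estimated at 150000 nM, within 40000 nM to 600000 nM. The step from compound 2 to compound 3 is expected to be a step that the limit leaves unreadable from compound 2 to compound 3.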

Compound 3, concentration for 50% growth inhibition: > 100000 nM
Compound 3 gave a limit, no number; the forecaster's own chance of this, stated with the estimate: 80%; the middle value lies beyond the limit too.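

Compound 3 sits at a limit of the assay, as do compound 1 and compound 2, so no step among these compounds can be read in this assay: the limit of > 100000 nM in this assay, at which 3 of the 3 values shown sit.

The compounds shown leave open whether any group at this place on the shared core gives a readable inhibition of growth.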